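From 2-fluorophenyl to a non-aromatic ring on the shared core

This account rests on a few compounds, and the source may have more. Where it says the series, first, only, none or still open, it means among the compounds named here.

Measured in a functional assay on NCI-H1993 cells (Homo sapiens) for inhibition, read by CCK-8 assay, with a stated time of 72 h; on this read-out lower numbers stand for stronger inhibition and higher numbers for weaker inhibition:
- Compound 1 `Cn1nccc1-c1cnc2ncn(Cc3ccc4ncccc4c3)c2n1`: 7910 nM
- Compound 2 `c1cnc2ccc(Cn3cnc4ncc(-c5cn[nH]c5)nc43)cc2c1`: 2890 nM
- Compound 3 `Fc1ccccc1-c1cnc2ncn(Cc3ccc4ncccc4c3)c2n1`: > 10000 nM

For compound 3 the read-out in this assay is only a limit of the assay, not a number. Compound 4 `C1=C(c2cnc3ncn(Cc4ccc5ncccc5c4)c3n2)CCNC1` has yet to be measured. It loses the 2-fluorophenyl of compound 3 and carries instead, on the same aromatic carbon, a six-membered non-aromatic ring with 1 hetero atom (a group of 6 heavy atoms (5 carbon, 1 nitrogen; one six-membered non-aromatic ring with 1 hetero atom) in place of a group of 7 heavy atoms (6 carbon, 1 fluorine; one six-membered aromatic ring of carbon only), on an aromatic carbon).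

Three measured steps at this place bear on the change. The largest of them is an at least 3.4-fold higher number from compound 2 to compound 3 (0.53 log units; beyond the scatter), while an at least 1.2-fold higher number from compound 1 to compound 3 (0.10 log units; that floor lies within the scatter) and a 2.7-fold lower number from compound 1 to compound 2 (0.44 log units; beyond the scatter). Both compounds without the 2-fluorophenyl gave numbers, so a modest move to a lower number is expected, though a result at the limit remains possible. Compound 2 stands at 2890 nM. Compound 1 stands at 7910 nM. The expected change is an at least 2.0-fold lower number from compound 3 to compound 4 (0.30 log units; that floor lies within the scatter). For compound 4 the estimated value is 5000 nM, with an expected range of 1500 nM to 15000 nM.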

Compound 4, half-maximal inhibitory concentration: 6660 nM
Beside the measured number, compound 4's estimate is 1.3-fold (0.12 log units) below it; low and high end bracket the measured number.
By their numbers in this assay, from the lowest: compound 2; then compounds 4 and 1 (each within the scatter of the next). At a limit, above all of these: compound 3.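

In this assay, the six-membered non-aromatic ring of compound 4 gives a number on this aromatic carbon, whereas the 2-fluorophenyl of compound 3 remains at a limit of the assay: the limit of > 10000 nM in this assay, at which 1 of the 4 values shown sits.

That limit leaves only a floor for the change, an at least 1.5-fold lower number from compound 3 to compound 4 (0.17 log units; that floor lies within the scatter). Compound 4 stands level with the 1-methyl-1H-pyrazol-5-yl group, a 1.2-fold lower number from compound 1 to compound 4 (0.07 log units; within the scatter), but the 1H-pyrazol-4-yl group keeps its lead, a 2.3-fold higher number from compound 2 to compound 4 (0.36 log units; beyond the scatter), so among these compounds an aromatic ring on this carbon is not needed for a measurable number, and only the 1H-pyrazol-4-yl group goes lower.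

Going by these compounds, what the ring nitrogen and the double bond of compound 4 each contribute stays open. A cyclohexenyl ring or a saturated piperidine ring on the same carbon would separate the two.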